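Trifluoromethoxy for Dimethylamino on the Shared Core

The source may report more compounds than this note shows. Statements on the series, on what has been measured and on what is new or still open speak of the compounds shown alone.

Of the compounds shown here, three have been measured in a functional assay on HCT-15 cells (Homo sapiens) for cytotoxicity, read by MTT assay, with a stated time of 2 days; on this read-out higher numbers stand for weaker inhibition and lower numbers for stronger inhibition.

Compound 1, `Cc1ccc2nc(-c3ccccc3C(F)(F)F)[nH]c(=O)c2c1`, gives > 50000 nM, a limit of the assay.
Compound 2, `CCN(CC)c1ccc2nc(-c3ccccc3N(C)C)[nH]c(=O)c2c1`, gives 4200 nM.
Compound 3, `Cc1ccc2nc(-c3ccccc3N(C)C)[nH]c(=O)c2c1`, gives > 50000 nM, again a limit of the assay.

Compound 3 thus stands at the upper edge of what this assay reports, a place it shares with compound 1, as the limit of > 50000 nM in this assay, at which 2 of the 3 values shown sit, shows. Among the compounds with values here, only one step to it can be read: an at least 11-fold higher number from compound 2 to compound 3 (1.07 log units; beyond the scatter). The other, a step that the two limits leave unreadable from compound 1 to compound 3, cannot be sized because both ends are limits. The unmeasured compound 4, `Cc1ccc2nc(-c3ccccc3OC(F)(F)F)[nH]c(=O)c2c1`, differs from compound 3 by trifluoromethoxy in place of dimethylamino on an aromatic carbon.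

Within the data shown here, no measured step covers this exact change. The nearest point of reference is compound 1, which carries trifluoromethyl on the same aromatic carbon and also sits at the limit, so a fluorinated group in this place has so far given no readable number. Compound 4 is therefore expected to stay at or near the limit, the expected step being a step that the limit leaves unreadable from compound 3 to compound 4, with no change beyond the scatter that the assay can resolve. The estimate for compound 4 in this assay is 80000 nM, within 20000 nM to 300000 nM, most likely reported only as a limit.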

Compound 4, half-maximal inhibitory concentration: 2790 nM
Compound 4: the middle estimate sits 29-fold (1.46 log units) above what was measured, and the stated range ends above it.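

In this assay, this aromatic carbon proves able to bring the shared core off the limit with methyl kept in place: trifluoromethoxy in place of dimethylamino gives an at least 17-fold lower number from compound 3 to compound 4 (1.25 log units; beyond the scatter). Until now, the only readable number had come with diethylamino in compound 2, so a change at this position alone had shown nothing, and a fluorinated group here does not by itself fix the outcome, as trifluoromethoxy in place of trifluoromethyl gives an at least 17-fold lower number from compound 1 to compound 4 (1.25 log units; beyond the scatter). Compound 1 and compound 3 both stay limits, so each of these steps gives a minimum size and not an exact one: the limit of > 50000 nM in this assay, at which 2 of the 4 values shown sit.

What the compounds shown leave open is whether this drop in the number belongs to trifluoromethoxy in particular or would also come with a methoxy group, a chlorine atom or a longer fluorinated ether on the same aromatic carbon. Within the data shown here, they also leave open what trifluoromethoxy would give on the shared core with diethylamino in place of methyl, the one other change that has produced a readable number.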